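Swapping a dichloropyrimidinyl amide for a cyanophenyl amide

A few compounds are considered here, and "the series" means these few. Any claim that something is new, unique, unknown or untested is made for them only; others in the source may bear on it.

The series shares one core, carried into three amides. Compound 1 `Cc1cc(C(=O)Nc2cccc(-c3oc4cc(-c5ccc(F)cc5)ccc4c(=O)c3O)c2)ccc1F` gives in a functional assay on HepG2 cells (Homo sapiens) for antiproliferative activity, read by CCK-8 assay, with a stated time of 72 h (on this read-out higher numbers stand for weaker inhibition and lower numbers for stronger inhibition), a value of 9540 nM. Compound 2 `O=C(Nc1cccc(-c2oc3cc(-c4ccc(F)cc4)ccc3c(=O)c2O)c1)c1ccc(Cl)nc1` gives in this assay 4610 nM, so that the change of a 2.1-fold lower number from compound 1 to compound 2 (0.32 log units; beyond the scatter) counts as modest. Compound 3 `O=C(Nc1cccc(-c2oc3cc(-c4ccc(F)cc4)ccc3c(=O)c2O)c1)c1cnc(Cl)nc1Cl` reaches in this assay only a limit, > 100000 nM, a point described by the limit of > 100000 nM in this assay, at which 1 of the 3 values shown sits. Thus compound 3 stands at the weak end of what has been measured, with steps of an at least 10-fold higher number from compound 1 to compound 3 (1.02 log units; beyond the scatter) and an at least 21-fold higher number from compound 2 to compound 3 (1.33 log units; beyond the scatter) leading to it.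

Compound 4 `N#Cc1ccc(C(=O)Nc2cccc(-c3oc4cc(-c5ccc(F)cc5)ccc4c(=O)c3O)c2)cc1` differs from compound 3 in one place: 4-cyanophenyl in place of 2,4-dichloropyrimidin-5-yl on a carbonyl carbon. The two steps that bear on this change are those into compound 3, both large and both towards higher numbers; leaving the 2,4-dichloropyrimidin-5-yl group is therefore expected to reverse them, moving back towards the range occupied by compound 1 and compound 2. Compound 4 is expected to show a step of an at least 12-fold lower number from compound 3 to compound 4 (1.09 log units; beyond the scatter) in this assay. For compound 4 the estimate is 8000 nM, within 2500 nM to 40000 nM.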

Compound 4, half-maximal inhibitory concentration: 7110 nM
The estimate for compound 4 lay 1.1-fold (0.05 log units) above the measured number; the measured number falls inside the stated range.
By their numbers in this assay, from the lowest: compounds 2, 4 and 1 (each within the scatter of the next, the first and the last beyond it). At a limit, above all of these: compound 3.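

With 4-cyanophenyl on the carbonyl carbon, the series comes back from the limit, with an at least 14-fold lower number from compound 3 to compound 4 (1.14 log units; beyond the scatter) in this assay. Compound 4 lies within the scatter of both other amides, with a 1.5-fold higher number from compound 2 to compound 4 (0.19 log units; within the scatter) and a 1.3-fold lower number from compound 1 to compound 4 (0.13 log units; within the scatter), so this position accepts a nitrile-bearing phenyl group without leaving the range those two compounds define. Among the four amides, only compound 3 stands apart, and its figure is a limit of the assay, not a number: the limit of > 100000 nM in this assay, at which 1 of the 4 values shown sits.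

The compounds shown leave open whether the weak result of compound 3 goes with its two chlorines or with the two nitrogens of its ring. They also leave open how an unsubstituted pyrimidin-5-yl group, or a phenyl group carrying a carboxylic acid or a morpholine, would read at this position.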